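The compounds below may be only part of what the source reports. "The series", "measured", "known", "first", "only" and "open" are said of these compounds alone.

For the measured compounds named here, in a functional assay for agonist activity at Free fatty acid receptor 1 (Homo sapiens), read by FLIPR, in the presence of a further agent that is not named here (a higher number here means that more compound is needed for the effect, a lower number that less compound is needed), compound 1 `Cc1ccc(Oc2ccc(CC3SC(=O)NC3=O)cc2)cc1C` gives 727 nM, the lowest of the three numbers measured so far. Compound 2 `COc1cc(Oc2ccc(Cl)cc2Cl)ccc1CC1SC(=O)NC1=O` gives 1410 nM, a gap to compound 1 that lies within the scatter, so the two cannot be told apart. Compound 3 `O=C1NC(=O)C(Cc2ccc(-c3ccccc3)cc2)S1` gives 2220 nM, and this gap to compound 1 lies beyond the scatter. Compound 4 `Cc1cccc(Oc2ccc(CC3SC(=O)NC3=O)cc2)c1` has not been measured; it differs from compound 1 in one place: hydrogen in place of methyl on an aromatic carbon. Going by the values given here, no measured pair shows what the loss of one methyl group does here. Expected is a small step, a 1.4-fold higher number from compound 1 to compound 4 (0.14 log units; within the scatter), a modest rise in the number if anything beyond the scatter. Compound 4 is therefore estimated at 1000 nM, between 400 nM and 2500 nM.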

Compound 4, half-maximal effective concentration: 203 nM
Beside the measured number, compound 4's estimate is 4.9-fold (0.69 log units) above it, and the stated range ends above it.
By their numbers in this assay, from the lowest: compound 4; then compounds 1, 2 and 3 (each within the scatter of the next, the first and the last beyond it).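

Hydrogen in place of methyl, on the aromatic carbon ortho to a methyl group and para to a large group, gives a 3.6-fold lower number from compound 1 to compound 4 (0.55 log units; beyond the scatter). For the compounds shown here, this is the first measured change in one place, and it shows that this position does not need a methyl group: less compound is needed without it. Nothing measured here explains the step. Still open, as far as these compounds go, is whether the remaining methyl group of compound 4 helps or hinders, and whether an ethyl group, a hydroxyl group or an amine at the emptied position would lower the number further.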